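This account rests on a few compounds, and the source may have more. Where it says the series, first, only, none or still open, it means among the compounds named here.

The numbers come from an ADME assay on HepG2 2.2.15 cells (Homo sapiens) for cytotoxicity, read by MTT assay, with a stated time of 8 days; a lower number here means that less compound is tolerated, a higher number that more compound is tolerated. Compound 2 `CC(=O)Nc1ccc(-c2nn(Cc3ccc(C#N)cc3)c(=O)c3ccccc23)c(F)n1` gives in this assay a value of > 100000 nM, which is a limit of the assay rather than a measured number. Compound 1 `N#Cc1ccc(Cn2nc(-c3cc(Cl)c(NC[C@H](O)CO)nc3F)c3ccccc3c2=O)cc1` likewise reaches only a limit in this assay, > 100000 nM. Both results sit at the limit of > 100000 nM in this assay, at which 2 of the 2 values shown sit, so the two compounds cannot be separated on the numbers shown, and compound 2 stands where the assay stops counting. Compound 3 `Cc1ccc(-c2nn(Cc3ccc(C#N)cc3)c(=O)c3ccccc23)c(F)n1` has not yet been measured in this assay. It differs from compound 2 by methyl in place of acetamido on an aromatic carbon. Because compound 2 stands at the limit of > 100000 nM in this assay, at which 2 of the 2 values shown sit, the change expected in this assay is a number no higher from compound 2 to compound 3 (the limit leaves the size open), that is, none beyond the scatter. For compound 3 the estimated value in this assay is 100000 nM, with a range from 30000 nM to 300000 nM, most likely again reported only as a limit.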

Compound 3, half-maximal cytotoxic concentration: > 100000 nM
Compound 3: only a limit was reported; the forecaster's own chance of this, stated with the estimate: 85%; the middle value lies on the limit itself.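

No step can be read from compound 2 to compound 3, because each result is only a limit in this assay: the limit of > 100000 nM in this assay, at which 3 of the 3 values shown sit.

The compounds shown leave open at what concentration any of them harms these cells, and whether methyl in place of acetamido changes that concentration.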